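Changing the aryl group on a shared core

The source may hold more compounds than are shown below. What is called first, only, known or untested is meant among the compounds shown, and "the series" means these compounds.

In a functional assay on MCF7 cells (Homo sapiens) for cytotoxicity, read by MTT assay, with a stated time of 48 h (a lower number here means a stronger inhibitor, a higher number a weaker inhibitor), compound 3 (`Cc1ccc(-c2nnc(SCCn3c([N+](=O)[O-])cnc3C)o2)c(O)c1`) gives 23500 nM. Compound 1 (`Cc1ncc([N+](=O)[O-])n1CCSc1nnc(-c2ccccc2N)o1`) gives 20100 nM, and the comparison shows a 1.2-fold higher number from compound 1 to compound 3 (0.07 log units; within the scatter), so these two stand level. Compound 2 (`Cc1ncc([N+](=O)[O-])n1CCSc1nnc(-c2ccc(F)cc2)o1`) gives 8100 nM, and the comparison shows a 2.9-fold higher number from compound 2 to compound 3 (0.46 log units; beyond the scatter). Compound 4 (`Cc1ncc([N+](=O)[O-])n1CCSc1nnc(-c2ccc(N)nc2)o1`) has not been measured. It carries 6-aminopyridin-3-yl in place of 2-hydroxy-4-methylphenyl on an aromatic carbon.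

All three measured steps change the group at this same place, and none is more than modest. Besides the two above, there is a 2.5-fold lower number from compound 1 to compound 2 (0.39 log units; beyond the scatter). Within the data shown here, no compound with a pyridine ring has been measured, so these steps bound the size of the change only loosely. Across the three compounds, swapping this group moves this assay little, so only a small step is expected, leaning towards a lower number and not clearly beyond the scatter. The expected change is a 1.6-fold lower number from compound 3 to compound 4 (0.19 log units; within the scatter). Compound 4 is estimated at 15000 nM, with an expected range of 6000 nM to 35000 nM.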

Compound 4, half-maximal inhibitory concentration: 26800 nM
Estimate against measurement, compound 4: 1.8-fold (0.25 log units) below; the range from low to high includes it.
By their numbers in this assay, from the lowest: compound 2; then compounds 1, 3 and 4 (each within the scatter of the next).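

In this assay, 6-aminopyridin-3-yl, the only ring with a hetero atom at this place among the compounds shown, stands level with 2-hydroxy-4-methylphenyl (with a 1.1-fold higher number from compound 3 to compound 4 (0.06 log units; within the scatter)) and with 2-aminophenyl (with a 1.3-fold higher number from compound 1 to compound 4 (0.12 log units; within the scatter)). Only 4-fluorophenyl stands apart (with a 3.3-fold higher number from compound 2 to compound 4 (0.52 log units; beyond the scatter)), so among these four compounds, the three whose aryl group carries an amine or a hydroxyl sit together, and compound 2, with fluorine, holds the lowest number. Nothing available gives a reason for this difference.

The compounds shown leave open whether a plain phenyl or a 4-chlorophenyl group would stand with compound 2 or with the other three. Going by these compounds, all of them keep the rest of the shared core unchanged, so how a longer chain in that core would move the number remains unknown.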